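Dropping the Nitro Group: Compound 1 to Compound 4

A few compounds are considered here, and "the series" means these few. Any claim that something is new, unique, unknown or untested is made for them only; others in the source may bear on it.

Compound 1 `COc1cc2c(cc1OC)CN(S(=O)(=O)c1ccc(-n3cc(COc4ccc([N+](=O)[O-])cc4)nn3)cc1)CC2` was tested in a functional assay on MOLT-3 cells (Homo sapiens) for cytotoxicity, read by MTT assay, with a stated time of 48 h; a lower number here means a stronger inhibitor, a higher number a weaker inhibitor. There compound 1 gives only a limit, > 50 ug/mL, not a number. Two related compounds share the same picture. Compound 2 `O=S(=O)(c1ccc(-n2cc(COc3ccccc3)nn2)cc1)N1CCc2ccccc2C1` gives a limit in this assay, > 50 ug/mL. Compound 3 `O=S(=O)(c1ccc(-n2cc(COc3ccc4ccccc4c3)nn2)cc1)N1CCc2ccccc2C1` likewise gives a limit, > 50 ug/mL. For the measured compounds named here, the one measured step, a step that the two limits leave unreadable from compound 2 to compound 3, therefore cannot be sized, and the whole set is described by the limit of > 50 ug/mL in this assay, at which 3 of the 3 values shown sit.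

Compound 4 `COc1cc2c(cc1OC)CN(S(=O)(=O)c1ccc(-n3cc(COc4ccccc4)nn3)cc1)CC2` differs from compound 1 by hydrogen in place of nitro on an aromatic carbon. No measured step involves this change, and every measured value sits at the limit, so nothing shown points to a direction for this step. The expectation is that compound 4 behaves like compound 1 and again reaches the limit rather than a readable number; the estimated step is a step that the limit leaves unreadable from compound 1 to compound 4, meaning no change beyond the scatter. Compound 4 is thus expected at 60 ug/mL, within a range of 30 ug/mL to 150 ug/mL.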

Compound 4, half-maximal inhibitory concentration: > 50 ug/mL
Compound 4 was reported as a limit (the forecaster's own chance of this, stated with the estimate: 80%); the middle value does not contradict the limit.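

No step can be read between compound 1 and compound 4, because both compounds stand at a limit of the assay and not at a number: the limit of > 50 ug/mL in this assay, at which 4 of the 4 values shown sit.

The compounds shown leave open which change, if any, would bring a readable number in this assay.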